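Series notes: amide core, amine substituent exchange at the aromatic nitrogen

The source may report more compounds than this note shows. Statements on the series, on what has been measured and on what is new or still open speak of the compounds shown alone.

Measured compounds:
compound 1 `Nc1cccc(Nc2c(C(=O)NCc3ccc(F)cc3)nc(Br)c3cccnc23)c1` — > 10000 nM
compound 2 `C[C@H](CO)Nc1nc(C(=O)NCc2ccc(F)cc2)c(O)c2ncccc12` — "not determined" (no result reported)

Compound 1 carries a 3-aminophenyl group on a nitrogen on an aromatic ring. In a functional assay on HCT-116 cells (Homo sapiens) for cytotoxicity, read by MTT assay, with a stated time of 72 h (a higher number here means a weaker inhibitor, a lower number a stronger inhibitor), compound 1 gives > 10000 nM, which is a limit of the assay rather than a number. Compound 2 has no result in this assay. Going by the values given here, the only fixed point in the set is therefore (the limit of > 10000 nM in this assay, at which 1 of the 2 values shown sits), so compound 1 stands at the weak end of what this assay can resolve, with no measured step to compare against.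

Compound 3 `COC(=O)CNc1c(C(=O)NCc2ccc(F)cc2)nc(Br)c2cccnc12` differs from compound 1 in one place: (methoxycarbonyl)methyl in place of 3-aminophenyl on a nitrogen on an aromatic ring. Among the compounds with values here, no measured pair in the set carries a change of this kind, so no direction can be read from the data. The step from compound 1 to compound 3 is expected to be a step that the limit leaves unreadable from compound 1 to compound 3, within the scatter. Compound 3 is estimated at 15000 nM, with a range from 3000 nM to 60000 nM, and most likely again only a limit in this assay.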

Compound 3, half-maximal inhibitory concentration: > 10000 nM
Compound 3 gave a limit, no number; the forecaster's own chance of this, stated with the estimate: 70%; the middle value does not contradict the limit.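

No new step can be read from compound 1 and compound 3, since each gives only a limit and not a number: the limit of > 10000 nM in this assay, at which 2 of the 3 values shown sit. Left open is whether any other substituent on this nitrogen brings the shared core to a measurable value in this assay.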